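A second fluoro on compound 2

A few compounds are considered here, and "the series" means these few. Any claim that something is new, unique, unknown or untested is made for them only; others in the source may bear on it.

Among the measured compounds shown here, in a functional assay on MDA-MB-231 cells (Homo sapiens) for inhibition, read by MTT assay, with a stated time of 5 days (a lower number here means a stronger inhibitor, a higher number a weaker inhibitor), compound 2 (`Cc1cc(Nc2nc(NCc3ccc(F)cc3)nc3[nH]ncc23)n[nH]1`) gives 8410 nM as the higher of the two numbers so far. Compound 3 (`Cc1cc(Nc2nc(NCc3ccc(F)cc3F)nc3[nH]ncc23)n[nH]1`) differs from it by one change (fluoro in place of hydrogen on an aromatic carbon), fluoro in place of hydrogen on an aromatic carbon. For the measured compounds named here, only one measured step bears on this (a 2.1-fold higher number from compound 1 to compound 2 (0.32 log units; beyond the scatter)), and it is modest. Compound 1 (`Cc1cc(Nc2nc(NCc3ccccc3Br)nc3[nH]ncc23)n[nH]1`) has a bromine ortho to a large group and gives 3990 nM as the lower number. A small drop is therefore expected, probably within the scatter (a 1.4-fold lower number from compound 2 to compound 3 (0.15 log units; within the scatter)). For compound 3 the estimated value is 6000 nM (2800 nM to 12000 nM).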

Compound 3, half-maximal inhibitory concentration: 2670 nM
Beside the measured number, compound 3's estimate is 2.2-fold (0.35 log units) above it; the measured number lies below the stated range.
By their numbers in this assay, from the lowest: compounds 3 and 1 (each within the scatter of the next); then compound 2.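

Adding a fluoro on the aromatic carbon ortho to a large group gives a 3.1-fold lower number from compound 2 to compound 3 (0.50 log units; beyond the scatter) in this assay, so this single change moves the number, which the earlier step, with its bromine swapped for a fluoro elsewhere on the ring, could not isolate. The 2,4-difluorophenyl and 2-bromophenyl groups cannot be told apart here, with a 1.5-fold lower number from compound 1 to compound 3 (0.17 log units; within the scatter). Nothing available explains the effect of the added fluoro. On these data alone, whether a chloro or a methoxy group on that same carbon would lower the number too remains open.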